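The source may report more compounds than this note shows. Statements on the series, on what has been measured and on what is new or still open speak of the compounds shown alone.

Compound 1 `CCc1cc(C(C)=O)c(O)cc1OCCCC(C)(C)C#N`: in an assay on isolated protein for binding affinity to leukotriene B4 receptor 1 (Homo sapiens), tested at 1 uM (on this read-out lower numbers stand for less inhibition and higher numbers for more inhibition at the one concentration tested (going by the name of the read-out)), compound 1 gives 46%.
Compound 2 `C=CCc1cc(C(C)=O)c(O)cc1OCCCC`: in this assay compound 2 gives 8%.
Compound 3 `C=CCc1cc(C(C)=O)c(O)cc1OCCCCC`: in this assay compound 3 gives 23%.

Compound 1 stands highest of the three, with compound 3 nearest and compound 2 furthest, both gaps beyond the scatter. Compound 4 `CCc1cc(C(C)=O)c(O)cc1OCCCCCCS(C)(=O)=O` has not yet been measured; it differs from compound 1 by 3-(methylsulfonyl)propyl in place of 1-cyano-1-methylethyl on a saturated chain carbon, three bonds along the chain from an oxygen on an aromatic ring. For the measured compounds named here, the only measured step of a related kind is a number 15 percentage points higher from compound 2 to compound 3 (beyond the scatter), which adds one carbon to the chain in place of hydrogen. The change here is larger and brings in a different group, so that step offers limited guidance. The step of a number 1 percentage points lower from compound 1 to compound 4 (within the scatter) is therefore expected to stay within the scatter. For compound 4 the estimate in this assay is 45%, ranging from 20% to 70%.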

Compound 4, a percentage reported as inhibition, at one concentration (the size of the read-out at that concentration, not a potency): 62%
Compound 4: middle estimate off by 17 percentage points, on the low side; the range from low to high includes it.
By their numbers in this assay, from the lowest: compound 2; then compound 3; then compound 1; then compound 4.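

On a saturated chain carbon, three bonds along the chain from an oxygen on an aromatic ring, 3-(methylsulfonyl)propyl in place of 1-cyano-1-methylethyl gives a number 16 percentage points higher from compound 1 to compound 4 (beyond the scatter) in this assay. A nitrile is therefore not needed at this position for inhibition at the one concentration tested, and a larger group with a sulfone can take its place. Nothing shown accounts for the gain. This single step changes the end group and the chain together, so their contributions cannot be separated. From the compounds shown here alone, whether an amine or a carboxylic acid would be accepted at the chain end also remains open.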